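The compounds below may be only part of what the source reports. "The series", "measured", "known", "first", "only" and "open" are said of these compounds alone.

Working notes on the series. In a functional assay on L1210 cells (Mus musculus) (a higher number here means a weaker inhibitor, a lower number a stronger inhibitor), compound 1 `CCCC/C=C\c1cn([C@H]2C[C@H](O)[C@@H](CO)O2)c(=O)[nH]c1=O` gives 361 ug/mL. Compound 2 `CCC#Cc1cn(C2O[C@H](CO)[C@@H](O)[C@@H]2O)c(=O)[nH]c1=O` reaches only the limit of this assay, > 1000 ug/mL. Compound 3 `CCC#Cc1cn([C@H]2C[C@H](O)[C@@H](CO)O2)c(=O)[nH]c1=O` likewise stands at the limit, > 1000 ug/mL, so its position is known only as a bound, and the limit of > 1000 ug/mL in this assay, at which 2 of the 3 values shown sit, is where two of the three values sit. Among the measured compounds shown here, the one measured step, an at least 2.7-fold higher number from compound 1 to compound 3 (0.44 log units; beyond the scatter), runs toward the weaker end. Compound 4 `CC(C)(C)C#Cc1cn([C@H]2C[C@H](O)[C@@H](CO)O2)c(=O)[nH]c1=O` differs from compound 3 by tert-butyl in place of ethyl on a triple-bonded carbon. For the measured compounds named here, no measured step bears on this change, and compound 3 itself is known only as a limit, so no step beyond the scatter is expected in this assay and compound 4 is most likely to remain at that limit as well. The estimate for compound 4 is 1000 ug/mL, in the range 300 ug/mL to 3000 ug/mL. The step expected is a number no higher from compound 3 to compound 4 (the limit leaves the size open).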

Compound 4, concentration for 50% inhibition: 287 ug/mL
Compound 4: the middle estimate sits 3.5-fold (0.54 log units) above what was measured; measured number outside the range, below it.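

Tert-butyl in place of ethyl on the triple-bonded carbon brings the series off the limit in this assay, with an at least 3.4-fold lower number from compound 3 to compound 4 (0.54 log units; beyond the scatter) as the first step seen at this place. The group carried on the triple-bonded carbon therefore matters, which compound 3 alone, known only as a limit, could not show. The change from hex-1-en-1-yl to 3,3-dimethylbut-1-yn-1-yl gives a 1.3-fold lower number from compound 1 to compound 4 (0.10 log units; within the scatter) and does not separate these two groups.

As far as these compounds go, the full size of the step to compound 4 stays open: the limit of > 1000 ug/mL in this assay, at which 2 of the 4 values shown sit. From the compounds shown here alone, whether a longer chain such as hex-1-yn-1-yl, or an amine, on the triple-bonded carbon would shift the number also stays open.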